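Cyclopropyl in place of isopropyl on a shared amide core

The compounds below may be only part of what the source reports. "The series", "measured", "known", "first", "only" and "open" are said of these compounds alone.

Compound 1 `CC(C)C(=O)N1CC2CC(C1)N2` reaches 86% in an assay on SH-EP1 cells for agonist activity at Neuronal acetylcholine receptor; alpha4/beta2 (Homo sapiens), read by FLIPR and calcium flux; a lower number here means a smaller maximal response, a higher number a larger maximal response. Its only comparator, compound 2 `O=C(CC1C=CCC1)N1CC2CC(C1)N2`, reaches 89% in this assay; the gap between the two numbers is within the scatter, so neither can be called stronger, and compound 1 simply sits at the bottom of the two values shown. Compound 3 `C[C@@H]1C[C@@H]1C(=O)N1CC2CC(C1)N2` differs from compound 1 by a group of 4 heavy atoms (4 carbon; one three-membered non-aromatic ring of carbon only) in place of a group of 3 heavy atoms (3 carbon; no ring), on a carbonyl carbon. Going by the values given here, with no step between measured compounds available, the account expects no change beyond the scatter, a step of a number 1 percentage points lower from compound 1 to compound 3 (within the scatter). Compound 3 is therefore estimated at 85% in this assay, in a range from 70% to 100%.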

Compound 3, largest response reached (Emax), in percent of the reference or control that the assay uses: 88%
Estimate against measurement, compound 3: 3 percentage points below, within the range that was stated.
By their numbers in this assay, from the lowest: compounds 1, 3 and 2 (each within the scatter of the next).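

Going by these compounds alone, this is the first step at this position that differs in one place: in this assay, the three-membered carbon ring group in place of isopropyl on the carbonyl carbon gives a number 2 percentage points higher from compound 1 to compound 3 (within the scatter). The two compounds therefore cannot be told apart in this read-out, and a ring of carbon only is tolerated here as far as this single pair shows. Nothing available gives a reason for this result. On these data alone, whether an amine or a carboxylic acid on this carbonyl carbon would also stay within the scatter remains open. So does the response of the other stereoisomers of the group in compound 3.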